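The source may report more compounds than this note shows. Statements on the series, on what has been measured and on what is new or still open speak of the compounds shown alone.

Of the compounds shown here, two from this series have been measured in an assay on isolated protein for inhibition of 3-hydroxy-3-methylglutaryl-coenzyme A reductase (Homo sapiens); a higher number here means a weaker inhibitor, a lower number a stronger inhibitor. Compound 1, `CC(C)c1cc(-c2ccc(F)cc2)c(-c2ccc(F)cc2)n1/C=C/[C@@H](O)C[C@@H](O)CC(=O)O`, gives 8.7 nM; 6.98 nM (2 entries), and compound 2, `CC(C)c1cc(-c2ccc(F)cc2)c(-c2cccc(Cl)c2)n1/C=C/[C@@H](O)C[C@@H](O)CC(=O)O`, gives 7.15 nM. These two differ in more than one place, so their numbers are simply set side by side; both sit in the same low range. Compound 2 rests on a single number, and a further measurement of it did not produce a single figure. The repeated measurements of compound 1, (the several entries of compound 1 in this assay, 8.7 nM; 6.98 nM (2 entries)), show how far one and the same compound can move between runs of this kind.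

Compound 3, `CC(C)c1cc(-c2ccc(F)cc2)c(-c2cccc(Br)c2)n1/C=C/[C@@H](O)C[C@@H](O)CC(=O)O`, has not yet been measured in this assay. It differs from compound 2 in one place: bromo in place of chloro on an aromatic carbon. Bromo in place of chloro on an aromatic carbon exchanges a halogen for another halogen, and no measured pair here shows what such a change does. No step beyond the usual scatter is expected; the step from compound 2 to compound 3 is estimated as a 1.0-fold lower number from compound 2 to compound 3 (0.01 log units; within the scatter). Compound 3 is therefore expected to give 7 nM, within 3.5 nM to 15 nM.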

Compound 3, half-maximal inhibitory concentration: 7.16 nM
For compound 3 the middle estimate is 1.0-fold (0.01 log units) below the measured one, and the stated range covers the measured number.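

Within the data shown here, compound 2 and compound 3 form the first pair in this set that differs in only one place, so this assay can now be read for a single change: bromo in place of chloro on an aromatic carbon, with a 1.0-fold higher number from compound 2 to compound 3 (0.00 log units; within the scatter). At this position on the 3-substituted phenyl ring, the two halogens cannot be told apart in this assay, although each is a single heavy atom of a different element. The step also has to be read against the movement of one and the same compound between repeated measurements, which is larger than anything seen in this pair: the several entries of compound 1 in this assay, 8.7 nM; 6.98 nM (2 entries).

This pair compares only two halogens at one position, so it says nothing about how the number would respond to a group of another kind there, such as a methoxy group, a nitrile or an amine. It also leaves open whether the same exchange of chloro for bromo would stay within the scatter on another carbon of that ring, or on the other phenyl ring of the shared core.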